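Methylating an Aromatic Nitrogen in a Kinase Inhibitor Series

A few compounds are considered here, and "the series" means these few. Any claim that something is new, unique, unknown or untested is made for them only; others in the source may bear on it.

Compound 1 `C[C@@H]1CCCN1c1c(C#N)c2c(N)ncnc2n1C` gives 15 nM in an assay on isolated protein for inhibition of Leucine-rich repeat serine/threonine-protein kinase 2 (Homo sapiens), read by TR-FRET and LanthaScreen, with stated times of 50 min and 30 min, in the presence of a further agent that is not named here; a lower number here means a stronger inhibitor, a higher number a weaker inhibitor. Compound 2 `C[C@@H]1CCCN1c1[nH]c2ncnc(N)c2c1C#N` gives 166 nM in this assay, and the change methyl in place of hydrogen on an aromatic nitrogen brings an 11-fold lower number from compound 2 to compound 1 (1.04 log units; beyond the scatter). Compound 3 `Cc1n[nH]cc1Nc1nc(N)c2c(C#N)c(N3CCC[C@H]3C)n(C)c2n1` gives 42 nM in this assay, and the step from compound 1 is a 2.8-fold higher number from compound 1 to compound 3 (0.45 log units; beyond the scatter). The difference between the cores of compound 2 and compound 3 is not broken down here.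

Compound 4 `Cc1nn(C)cc1Nc1nc(N)c2c(C#N)c(N3CCC[C@H]3C)n(C)c2n1` is not yet measured; it differs from compound 3 by methyl in place of hydrogen on an aromatic nitrogen. This is the same kind of change as from compound 2 to compound 1, but at a different place: there the nitrogen belongs to a five-membered aromatic ring with 1 nitrogen, part of a fused or bridged system of two rings, next to the ring atom that bears a 2-methylpyrrolidin-1-yl group and two ring bonds from the ring atom that bears a cyano group; here it belongs to a five-membered aromatic ring with 2 nitrogen, next to the ring nitrogen, two ring bonds from the ring atom that bears a large group and two ring bonds from the ring atom that bears a methyl group. Because the earlier step of an 11-fold lower number from compound 2 to compound 1 (1.04 log units; beyond the scatter) was made at another place, it is only a loose guide, and compound 4 is expected to show a smaller step of a 1.4-fold lower number from compound 3 to compound 4 (0.15 log units; within the scatter). Compound 4 is estimated at 30 nM in this assay, between 12 nM and 80 nM.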

Compound 4, half-maximal inhibitory concentration: 38 nM
For compound 4 the middle estimate is 1.3-fold (0.10 log units) below the measured one; low and high end bracket the measured number.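

Methyl in place of hydrogen on an aromatic nitrogen does not carry over as a fixed step between these cores in this assay: the same change on two cores in this assay, an 11-fold lower number (1.04 log units; beyond the scatter) from compound 2 to compound 1 and a 1.1-fold lower number (0.04 log units; within the scatter) from compound 3 to compound 4, 10-fold (1.00 log units) apart, beyond the scatter of two such steps On the five-membered aromatic ring with 2 nitrogen the change gives only a 1.1-fold lower number from compound 3 to compound 4 (0.04 log units; within the scatter), and the (1,3-dimethyl-1H-pyrazol-4-yl)amino group on the core of compound 1 gives a 2.5-fold higher number from compound 1 to compound 4 (0.40 log units; beyond the scatter). With one pair at each place, the data do not show why the two steps differ or whether the place of the methyl alone sets their size.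

The compounds shown leave open how an ethyl group or a longer chain on that same nitrogen would read in this assay. They also leave open whether methyl on the nitrogen of the shared core would give as large a step with the (3-methyl-1H-pyrazol-4-yl)amino group present.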